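The compounds below may be only part of what the source reports. "The series", "measured", "known", "first", "only" and "open" are said of these compounds alone.

Of the compounds shown here, three sharing one core have been measured in a functional assay on MCF7 cells (Homo sapiens) for cytotoxicity, read by MTT assay, with a stated time of 72 h; a lower number here means a stronger inhibitor, a higher number a weaker inhibitor. Compound 1 (`COc1ccc(/C=C2\CCC/C(=C\c3ccccc3Br)C2=O)cc1OC`) gives 9500 nM, compound 2 (`COc1cccc(/C=C2\CCC/C(=C\c3ccc(OC)c(OC)c3)C2=O)c1`) gives 4600 nM, and compound 3 (`COc1ccc(/C=C2\CCC/C(=C\c3ccc(OC)c(OC)c3)C2=O)cc1`) gives 7800 nM. Compound 3 cannot be told apart from either of the others, with a 1.2-fold lower number from compound 1 to compound 3 (0.09 log units; within the scatter) and a 1.7-fold higher number from compound 2 to compound 3 (0.23 log units; within the scatter). Compound 4 (`COc1ccc(/C=C2\CCC/C(=C\c3cccc(O)c3)C2=O)cc1OC`) has 3-hydroxyphenyl in place of 4-methoxyphenyl on a double-bonded chain carbon bound to a double-bonded ring carbon. All three measured steps are swaps at this same place, and the only one that clears the scatter is modest, a 2.1-fold lower number from compound 1 to compound 2 (0.31 log units; beyond the scatter). Going by the values given here, none of the measured compounds carries 3-hydroxyphenyl, so the data offer no direct precedent for this group. On the size of those steps, no change beyond the scatter is expected in this assay. The expected step is a 1.4-fold lower number from compound 3 to compound 4 (0.15 log units; within the scatter). Compound 4 is estimated at 5500 nM, with an expected range of 2200 nM to 13000 nM.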

Compound 4, half-maximal inhibitory concentration: 2900 nM
Beside the measured number, compound 4's estimate is 1.9-fold (0.28 log units) above it; the range from low to high includes it.
By their numbers in this assay, from the lowest: compounds 4, 2, 3 and 1 (each within the scatter of the next, the first and the last beyond it).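

In this assay, going by these compounds alone, 3-hydroxyphenyl at this place gives the first step beyond the scatter that involves 4-methoxyphenyl (a 2.7-fold lower number from compound 3 to compound 4 (0.43 log units; beyond the scatter)) and the largest step seen so far (a 3.3-fold lower number from compound 1 to compound 4 (0.52 log units; beyond the scatter)). The hydroxyl is not separated from its methyl ether, however: hydrogen in place of methyl on an oxygen on an aromatic ring gives only a 1.6-fold lower number from compound 2 to compound 4 (0.20 log units; within the scatter), so the data set 3-hydroxyphenyl apart from 4-methoxyphenyl but not from 3-methoxyphenyl. No measurement at hand accounts for these steps.

The compounds shown leave open whether the hydroxyl counts only in the group 3-hydroxyphenyl or would read the same as 4-hydroxyphenyl. They also leave open how a phenyl ring carrying an amine or a carboxylic acid would compare at this place.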